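Chloro on compound 2: working notes

This account rests on a few compounds, and the source may have more. Where it says the series, first, only, none or still open, it means among the compounds named here.

Compound 1 (`O=C(CCCCC(S)CCS)Nc1cccc(C(F)(F)F)c1`) gives 8.41%
Compound 2 (`O=C(CCCCC(CCSC(=O)c1ccccc1)SC(=O)c1ccccc1)Nc1ccccc1`) gives 1.52%

In a functional assay on KB cells (Homo sapiens) for inhibition, read by MTT assay, with a stated time of 24 h, tested at 0.1 ug/mL (a higher number here means more inhibition of growth at the concentration tested, a lower number less inhibition of growth), compound 2 stands within the scatter of compound 1 and no gap can be read between them. Compound 3 (`O=C(CCCCC(CCSC(=O)c1ccccc1)SC(=O)c1ccccc1)Nc1ccc(Cl)cc1`) carries chloro in place of hydrogen on an aromatic carbon, para to a large group (chloro in place of hydrogen on an aromatic carbon). Within the data shown here, no measured step for such a change is available, so no step beyond the scatter is expected in this assay here. The expectation rests on compound 2 at 1.52% as the starting value. The estimate is a small shift (a number 2.5 percentage points higher from compound 2 to compound 3 (within the scatter)) that stays within the scatter. Compound 3 is expected at 4% with an estimated range of 0% to 14% in this series.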

Compound 3, percent growth inhibition at one concentration: 17%
Compound 3: the middle estimate sits 13 percentage points below what was measured; measured number above the stated range.
By their numbers in this assay, from the lowest: compounds 2, 1 and 3 (each within the scatter of the next, the first and the last beyond it).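

In this assay, among these compounds, chloro in place of hydrogen on an aromatic carbon, para to a large group, gives a number 15.5 percentage points higher from compound 2 to compound 3 (beyond the scatter) and is the only single-place step so far. This shows that the read-out can respond to a change at this carbon of the anilide ring, far from the two benzoyl thioester groups. No measurement available here accounts for the step.

Open, going by these compounds, is whether this response is specific to chloro, or whether a methoxy group or an amine at the same carbon would give a similar step. Also open, on these data alone, is whether chloro on another carbon of the ring would do so.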